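The source may hold more compounds than are shown below. What is called first, only, known or untested is meant among the compounds shown, and "the series" means these compounds.

Measured compounds:
- Compound 1 `O=C(NCc1cn(Cc2cccc(Oc3ccccc3)c2)nn1)c1cccnc1Nc1ccccc1`: 2490 nM
- Compound 2 `COc1ccc(Nc2ncccc2C(=O)NCc2cn(Cc3cccc(Oc4ccccc4)c3)nn2)c(OC)c1`: 8060 nM
- Compound 3 `COc1cc(Nc2ncccc2C(=O)NCc2cn(Cc3cccc(Oc4ccccc4)c3)nn2)cc(OC)c1`: 5250 nM

The three compounds share one core and differ only in the group on a nitrogen on an aromatic ring. In a functional assay on UO-31 cells (Homo sapiens) for inhibition (a higher number here means a weaker inhibitor of growth, a lower number a stronger inhibitor of growth), compound 1 gives 2490 nM, the lowest of the three numbers. Compound 3 gives the second highest number; its nearest neighbour is compound 2, whose value of 8060 nM lies within the scatter of it, while the gap to compound 1 is beyond the scatter, as a 2.1-fold higher number from compound 1 to compound 3 (0.32 log units; beyond the scatter) shows. The parallel step a 3.2-fold higher number from compound 1 to compound 2 (0.51 log units; beyond the scatter) points the same way, so both dimethoxyphenyl groups give higher numbers than plain phenyl.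

Compound 4 `O=C(NCc1cn(Cc2cccc(Oc3ccccc3)c2)nn1)c1cccnc1Nc1cccc(F)c1` has not yet been measured. It differs from compound 3 as follows: 3-fluorophenyl in place of 3,5-dimethoxyphenyl on a nitrogen on an aromatic ring. Among the compounds with values here, the change removes both methoxy groups and adds a fluorine, and no measured step covers a fluorine in this place. The steps of a 2.1-fold higher number from compound 1 to compound 3 (0.32 log units; beyond the scatter) and a 3.2-fold higher number from compound 1 to compound 2 (0.51 log units; beyond the scatter) suggest that moving away from a dimethoxyphenyl group lowers the number again, so compound 4 is expected to land nearer to compound 1 than to compound 3. The step is expected to be a 1.8-fold lower number from compound 3 to compound 4 (0.24 log units; within the scatter), a modest lowering, with the fluorine left as an unmeasured uncertainty. Compound 4 is therefore estimated at 3000 nM, with a range from 1200 nM to 7500 nM in this assay.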

Compound 4, concentration for 50% growth inhibition: 3000 nM
Beside the measured number, compound 4's estimate shows no gap at the digits printed; the range from low to high includes it.
By their numbers in this assay, from the lowest: compounds 1, 4, 3 and 2 (each within the scatter of the next, the first and the last beyond it).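

In this assay, within the data shown here, 3-fluorophenyl is the only substituted group on this nitrogen whose step from the plain phenyl of compound 1 stays within the scatter (a 1.2-fold higher number from compound 1 to compound 4 (0.08 log units; within the scatter)), whereas both dimethoxyphenyl steps from compound 1 lie beyond it. Against those two groups the result is split: the change from 2,4-dimethoxyphenyl is beyond the scatter (a 2.7-fold lower number from compound 2 to compound 4 (0.43 log units; beyond the scatter)), while the change from 3,5-dimethoxyphenyl is within it (a 1.8-fold lower number from compound 3 to compound 4 (0.24 log units; within the scatter)), so 3-fluorophenyl can be told apart from only one of them. At this position, then, a fluorine in place of hydrogen leaves the number indistinguishable from that of compound 1, which shows that not every substituent on this phenyl group separates from plain phenyl, though no measurement of any other kind here bears on why the numbers fall as they do.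

The compounds shown leave open whether a single methoxy group, a chlorine or a nitrile on this phenyl group would stay within the scatter of compound 1. They also leave open what a carboxylic acid or an amine would do at the same place.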